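Swapping a branched chain for tert-butyl in compound 4

The source may hold more compounds than are shown below. What is called first, only, known or untested is meant among the compounds shown, and "the series" means these compounds.

The three measured compounds share one core and differ only in the group attached to the double-bonded nitrogen. Compound 1 `CCC(CC)/N=C(\NC#N)Nc1ccncc1` gives 2.5 mg/kg in a functional assay on the whole organism (blood, strain Wistar-Okamoto) with Rattus norvegicus as the target, with a stated time of 5 days; a lower number here means that less compound is needed, a higher number that more compound is needed for the effect. Compound 2 `CCC(C)C(C)/N=C(\NC#N)Nc1ccncc1` gives 8 mg/kg, and compound 3 `CC(/N=C(\NC#N)Nc1ccncc1)C1CC1` gives 3 mg/kg. Compound 3 therefore sits second highest of the three numbers: against compound 1 the gap is a 1.2-fold higher number from compound 1 to compound 3 (0.08 log units; within the scatter), while against compound 2 it is a 2.7-fold lower number from compound 2 to compound 3 (0.43 log units; beyond the scatter).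

Compound 4 `CC(C)(C)/N=C(\NC#N)Nc1ccncc1` has not yet been tested. It differs from compound 3 by tert-butyl in place of 1-cyclopropylethyl on a double-bonded nitrogen. Among the measured compounds shown here, two measured steps bear on this. The change between compound 1 and compound 3, a 1.2-fold higher number from compound 1 to compound 3 (0.08 log units; within the scatter), shows that reshaping a branched group of similar size leaves this assay essentially unchanged. The step of a 3.2-fold higher number from compound 1 to compound 2 (0.51 log units; beyond the scatter) shows that a longer branched chain raises the number modestly. tert-Butyl is smaller and compact, so the expected step is a 1.2-fold lower number from compound 3 to compound 4 (0.08 log units; within the scatter), with no move beyond the scatter. Compound 4 is estimated at 2.5 mg/kg, likely between 1.2 mg/kg and 6 mg/kg.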

Compound 4, minimum effective dose: 2.5 mg/kg
Estimate against measurement, compound 4: no gap at the digits printed; low and high end bracket the measured number.
By their numbers in this assay, from the lowest: compounds 1, 4 and 3 (each within the scatter of the next); then compound 2.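

At this place on a double-bonded nitrogen, this assay shows a 1.2-fold lower number from compound 3 to compound 4 (0.08 log units; within the scatter) when tert-butyl replaces 1-cyclopropylethyl, and no change at the digits printed from compound 1 to compound 4 (within the scatter) when it replaces pentan-3-yl, so neither the three-membered ring of compound 3 nor the 5 heavy atoms of the groups in compounds 1 and 3 are needed to keep the number in this range. Compound 2, with 1,2-dimethylbutyl, remains the one that stands apart, at a 3.2-fold lower number from compound 2 to compound 4 (0.51 log units; beyond the scatter) for the change to tert-butyl. Nothing measured here explains this pattern.

The compounds shown leave open whether a smaller group such as methyl or isopropyl would keep the number in the same range. They also leave open what a longer straight chain such as n-pentyl, or a chain carrying an amine or a hydroxyl, would do here.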